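The source may report more compounds than this note shows. Statements on the series, on what has been measured and on what is new or still open speak of the compounds shown alone.

Measured so far:
- compound 1, `CC(C)C(=O)OCOC(=O)C1=C(S[C@@H]2CN[C@H](C(=O)Nc3cccc(C(=O)OCOC(=O)C(C)C)c3)C2)[C@H](C)[C@@H]2[C@@H]([C@@H](C)O)C(=O)N12`; in a physicochemical assay for metabolic stability, read by LC-MS, in phosphate buffer, with a stated time of 3 h, at pH 7.4, tested at 50 uM (a higher number here means that more of the compound is left, a lower number that less of the compound is left), compound 1 gives > 95%, which is a limit of the assay and not a number.
- compound 2, `CCCCOC(=O)C1=C(S[C@@H]2CN[C@H](C(=O)Nc3cccc(C(=O)OCCCC)c3)C2)[C@H](C)[C@@H]2[C@@H]([C@@H](C)O)C(=O)N12`; compound 2 gives > 95%, again a limit.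
- compound 3, `CC(C)C(=O)OCOC(=O)c1cccc(NC(=O)[C@@H]2C[C@H](SC3=C(C(=O)O)N4C(=O)[C@H]([C@@H](C)O)[C@H]4[C@H]3C)CN2)c1`; compound 3 gives > 95%, again a limit.

Compound 1 therefore stands at the upper limit of this assay, and so do the other two measured compounds, which is what the limit of > 95% in this assay, at which 3 of the 3 values shown sit, records. Nothing distinguishes the three within the numbers shown.

Compound 4, `CC(C)C(=O)OCOC(=O)C1=C(S[C@@H]2CN[C@H](C(=O)Nc3cccc(C(=O)O)c3)C2)[C@H](C)[C@@H]2[C@@H]([C@@H](C)O)C(=O)N12`, arises from compound 1 by the change (hydrogen in place of ((isopropylcarbonyl)oxy)methyl on an oxygen next to a carbonyl group). Going by the values given here, the one measured step that bears on it is the step from compound 1 to compound 3, a step that the two limits leave unreadable from compound 1 to compound 3, where the same group leaves from another oxygen next to a carbonyl group; both ends of that step sit at the limit, so its size cannot be read. A step of readable size, in either direction, is thus not to be expected for compound 4 in this assay, only a value at or near the same limit.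

Compound 4 is therefore estimated to give 96%, within a range from 88% to 100%, which means an expected step that the limit leaves unreadable from compound 1 to compound 4.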

Compound 4, percent of the compound remaining: > 95%
Compound 4 gave a limit, no number; the forecaster's own chance of this, stated with the estimate: 80%; the middle value is on the limit's open side.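

No step can be read from compound 1 to compound 4, because both sit at the same limit: the limit of > 95% in this assay, at which 4 of the 4 values shown sit.

The compounds shown leave open whether hydrogen in place of ((isopropylcarbonyl)oxy)methyl changes how much compound is left in this assay at all, and whether any of the four compounds truly differs from the others there.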